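Working notes: vinyl to prop-1-en-1-yl on compound 2

This account rests on a few compounds, and the source may have more. Where it says the series, first, only, none or still open, it means among the compounds named here.

Measured compounds:
compound 1, `CCOC(=O)c1cc(-c2ccc(Oc3ccccc3)cc2)nn1Cc1cccc(NC(=O)CCl)c1`, 400 nM
compound 2, `C=CC(=O)Nc1ccc(Cn2nc(-c3ccc(Oc4ccccc4)cc3)cc2C(=O)OCC)cc1`, 12500 nM

In a functional assay on Z-138 cells (Homo sapiens) for inhibition, read by luminescence and CellTiter-Glo, with a stated time of 72 h (on this read-out higher numbers stand for weaker inhibition and lower numbers for stronger inhibition), compound 2 gives 12500 nM, the higher of the two numbers; compound 1 gives 400 nM. For the measured compounds named here, the only measured step, a 31-fold higher number from compound 1 to compound 2 (1.49 log units; beyond the scatter), changes a different part of the molecule. Compound 3 `C/C=C/C(=O)Nc1ccc(Cn2nc(-c3ccc(Oc4ccccc4)cc3)cc2C(=O)OCC)cc1` differs from compound 2 by prop-1-en-1-yl in place of vinyl on a carbonyl carbon. Going by the values given here, no measured step bears on this change, so no step beyond the scatter is expected in this assay. The expected step is a 1.2-fold higher number from compound 2 to compound 3 (0.08 log units; within the scatter). Compound 3 is estimated at 15000 nM, within 5000 nM to 45000 nM.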

Compound 3, half-maximal inhibitory concentration: > 60000 nM
Compound 3: only a limit was reported (the forecaster's own chance of this, stated with the estimate: 20%); middle value at least 4.0-fold (0.60 log units) away from the limit.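

The carbonyl carbon is sensitive to even this small change: in this assay, prop-1-en-1-yl in place of vinyl gives an at least 4.8-fold higher number from compound 2 to compound 3 (0.68 log units; beyond the scatter). Compound 3 has only a limit, not a number: the limit of > 60000 nM in this assay, at which 1 of the 3 values shown sits.

Replacing 3-(((chloromethyl)carbonyl)amino)phenyl with 4-(((prop-1-en-1-yl)carbonyl)amino)phenyl gives an at least 150-fold higher number from compound 1 to compound 3 (2.17 log units; beyond the scatter).

Still open, from the compounds shown here alone, is how a longer chain or an amine on the vinyl group would read here. The compounds shown also do not separate the effect of the attachment position from that of the carbonyl substituent, as 3-((vinylcarbonyl)amino)phenyl would.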